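The source may report more compounds than this note shows. Statements on the series, on what has been measured and on what is new or still open speak of the compounds shown alone.

In a functional assay on MDA-MB-231 cells (Homo sapiens) for inhibition, read by sulforhodamine B assay, with a stated time of 48 h (a lower number here means a stronger inhibitor of growth, a higher number a weaker inhibitor of growth), compound 3 (`COc1ccc2c(c1)NC(=O)CN2c1nc(NC2CCCC2)nc2ccccc12`) gives 17.6 nM. Compound 1 (`COc1ccc2c(c1)NC(=O)CN2c1nc(COC(C)=O)nc2ccccc12`) gives 8.95 nM, and compound 2 (`COc1ccc2c(c1)NC(=O)CN2c1nc(COCCCC(=O)NO)nc2ccccc12`) gives 1020 nM. Compound 4 (`COc1ccc2c(c1)NC(=O)CN2c1nc(N2CC(OC)C2)nc2ccccc12`) has 3-methoxyazetidin-1-yl in place of cyclopentylamino on an aromatic carbon, between two ring nitrogen atoms: 3-methoxyazetidin-1-yl in place of cyclopentylamino on an aromatic carbon. Two measured changes at this carbon bear on it. One is a 2.0-fold higher number from compound 1 to compound 3 (0.29 log units; within the scatter), and the other, involving the long hydroxycarbamoyl chain, is a 58-fold lower number from compound 2 to compound 3 (1.76 log units; beyond the scatter). For the measured compounds named here, compound 4 has no such chain, so the first step is the closer guide, although no measured compound carries an azetidine. The expected step is a 1.2-fold lower number from compound 3 to compound 4 (0.07 log units; within the scatter), which would not go beyond the scatter. Compound 4 is estimated at 15 nM, with an expected range of 4 nM to 60 nM.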

Compound 4, concentration for 50% growth inhibition: 53.1 nM
Compound 4: the middle estimate sits 3.5-fold (0.55 log units) below what was measured; the measured number falls inside the stated range.
By their numbers in this assay, from the lowest: compounds 1 and 3 (each within the scatter of the next); then compound 4; then compound 2.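

In this assay, cyclopentylamino and acetoxymethyl at this aromatic carbon between two ring nitrogen atoms had stood within the scatter of each other, but 3-methoxyazetidin-1-yl separates from both (a 3.0-fold higher number from compound 3 to compound 4 (0.48 log units; beyond the scatter); a 5.9-fold higher number from compound 1 to compound 4 (0.77 log units; beyond the scatter)). Cyclopentylamino and 3-methoxyazetidin-1-yl have the same heavy-atom count, so that count alone does not set the number here, while compound 4 still remains well clear of the long chain (a 19-fold lower number from compound 2 to compound 4 (1.28 log units; beyond the scatter)). No measurement on hand accounts for these differences.

From the compounds shown here alone, whether the four-membered ring or its methoxy group drives the step remains open. Plain azetidin-1-yl and pyrrolidin-1-yl would help separate the two.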